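The source may hold more compounds than are shown below. What is called first, only, known or untested is meant among the compounds shown, and "the series" means these compounds.

Working notes on the series, read in an ADME assay on HepG2 cells (Homo sapiens) for cytotoxicity, in the presence of a further agent that is not named here; on this read-out lower numbers stand for stronger inhibition and higher numbers for weaker inhibition. Compound 1 `CN(Cc1ccccc1)C(=O)c1nc(Cc2ccccc2C(F)(F)F)n(C)c(=O)c1O` gives > 100000 nM, and this is a limit of the assay, not a number. Compound 2 `Cc1nc(C(=O)NCc2ccccc2)c(O)c(=O)n1C` gives > 100000 nM, which is also a limit. The position of compound 1 is therefore known only as a limit, and the same holds for the whole set so far: the limit of > 100000 nM in this assay, at which 2 of the 2 values shown sit. Among the compounds with values here, no step between measured compounds is available to size any structural change on the shared core.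

Compound 3 `Cn1c(Cc2ccccc2C(F)(F)F)nc(C(=O)NCc2ccccc2F)c(O)c1=O` carries (2-fluorobenzyl)amino in place of benzyl(methyl)amino on a carbonyl carbon. The change gains a hydrogen-bond donor and a fluorine, while the heavy-atom count stays level. In this assay no step beyond the scatter is expected, in either direction. That expectation rests on compound 1, which sits at its limit of > 100000 nM. The expected size is a number no higher from compound 1 to compound 3 (the limit leaves the size open), and a report of a limit alone is the likeliest outcome. For compound 3 the estimate is 100000 nM, with an expected range of 50000 nM to 200000 nM.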

Compound 3, half-maximal inhibitory concentration: > 100000 nM
Compound 3 ended at the assay's limit (the forecaster's own chance of this, stated with the estimate: 80%); the middle value lies on the limit itself.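

Within the data shown here, compound 1 and compound 3 both sit at a limit of the assay rather than at a number, so no step between them can be read, and the same holds for the whole set: the limit of > 100000 nM in this assay, at which 3 of the 3 values shown sit. The compounds shown leave open whether any change on the shared core gives a measurable value in this assay.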